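Swapping a Methyl for Chlorine on the Phenol Ring

The source may report more compounds than this note shows. Statements on the series, on what has been measured and on what is new or still open speak of the compounds shown alone.

Compound 3 `Cc1cc(-c2ccc(C(=O)N(C)c3ccccc3C)o2)ccc1O` gives the lowest number of the three measured compounds in an assay on T47D cells for inhibition of 17-beta-hydroxysteroid dehydrogenase type 1 (Homo sapiens), read by HPLC, with a stated time of 24 h (a lower number here means a stronger inhibitor, a higher number a weaker inhibitor), with 8.6 nM. Compound 1 `Cc1ccccc1N(C)C(=O)c1ccc(-c2ccc(O)cc2)o1` shows 21 nM and compound 2 `Cc1ccccc1N(C)C(=O)c1ccc(-c2ccccc2O)o1` shows 1900 nM; the step of a 2.4-fold lower number from compound 1 to compound 3 (0.39 log units; beyond the scatter) is modest, whereas a 90-fold higher number from compound 1 to compound 2 (1.96 log units; beyond the scatter) is large. Compound 4 `Cc1ccccc1N(C)C(=O)c1ccc(-c2ccc(O)cc2Cl)o1` differs from compound 3 by 2-chloro-4-hydroxyphenyl in place of 4-hydroxy-3-methylphenyl on an aromatic carbon. The hydroxyl position that compound 2 lost is kept here, so the large penalty seen in a 220-fold lower number from compound 2 to compound 3 (2.34 log units; beyond the scatter) is not expected to reappear. Among the compounds with values here, the methyl gain of a 2.4-fold lower number from compound 1 to compound 3 (0.39 log units; beyond the scatter) is given up, and no measured step shows what a chlorine does. The expectation for compound 4 is therefore a modest rise, a 3.5-fold higher number from compound 3 to compound 4 (0.54 log units; beyond the scatter), to about 30 nM, within 8 nM to 120 nM.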

Compound 4, half-maximal inhibitory concentration: 14 nM
Estimate against measurement, compound 4: 2.1-fold (0.33 log units) above; the measured number falls inside the stated range.
By their numbers in this assay, from the lowest: compounds 3, 4 and 1 (each within the scatter of the next, the first and the last beyond it); then compound 2.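

In this assay, adding a chlorine to the hydroxyphenyl ring of compound 1 gives a 1.5-fold lower number from compound 1 to compound 4 (0.18 log units; within the scatter) and so does not clearly change the number. Exchanging the 4-hydroxy-3-methylphenyl of compound 3 for 2-chloro-4-hydroxyphenyl gives a 1.6-fold higher number from compound 3 to compound 4 (0.21 log units; within the scatter) and likewise separates nothing. Replacing 2-hydroxyphenyl with 2-chloro-4-hydroxyphenyl gives a 140-fold lower number from compound 2 to compound 4 (2.13 log units; beyond the scatter) and shows that the chlorine-bearing ring stays with the low-number compounds. No measured evidence here explains these results. Still open, from the compounds shown here alone, is how a methoxy group or an amine would read in place of the chlorine.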